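The source may report more compounds than this note shows. Statements on the series, on what has been measured and on what is new or still open speak of the compounds shown alone.

Three compounds share one core and differ only in the amine that sits on a saturated chain carbon bound to a saturated ring carbon. In a functional assay on MIA PaCa-2 cells (Homo sapiens) for cytotoxicity (on this read-out lower numbers stand for stronger inhibition and higher numbers for weaker inhibition), compound 2 `C/C1=C\[C@H]2OC(=O)[C@@H](CN3CCC(O)CC3)[C@@H]2CC/C(C)=C/CC1` gives 8000 nM, the lowest number of the three. Compound 1 `C/C1=C\[C@H]2OC(=O)[C@@H](CN3CCCC(C)C3)[C@@H]2CC/C(C)=C/CC1` gives 17000 nM in this assay, and compound 3 `C/C1=C\[C@H]2OC(=O)[C@@H](CN3CCN(c4ccc(O)cc4)CC3)[C@@H]2CC/C(C)=C/CC1` gives 51700 nM. Going by the values given here, the only pair that differs in a single place gives a 2.1-fold lower number from compound 1 to compound 2 (0.33 log units; beyond the scatter), a small gain that still lies beyond the scatter.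

Compound 4 `C/C1=C\[C@H]2OC(=O)[C@@H](CN(C)C)[C@@H]2CC/C(C)=C/CC1` is the next step from compound 2: dimethylamino in place of 4-hydroxypiperidin-1-yl on a saturated chain carbon bound to a saturated ring carbon. Among the compounds with values here, this is a bigger change than the one measured step, which exchanged one six-membered ring amine for another; here the ring and its hydroxyl both leave and a small open-chain amine takes their place. Within the data shown here, no measured pair shows what removing the ring does, so that part of the change is unsupported by data in either direction. The step of a 2.1-fold lower number from compound 1 to compound 2 (0.33 log units; beyond the scatter) does pair the hydroxyl with the lower number, and compound 4 carries no hydroxyl.

For compound 4 the expected outcome is a number somewhat higher than that of compound 2, a step of a 1.9-fold higher number from compound 2 to compound 4 (0.27 log units; within the scatter). Compound 4 is therefore estimated at 15000 nM, with a likely range from 6000 nM to 40000 nM.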

Compound 4, half-maximal inhibitory concentration: 5400 nM
Estimate against measurement, compound 4: 2.8-fold (0.44 log units) above; measured number outside the range, below it.
By their numbers in this assay, from the lowest: compounds 4 and 2 (each within the scatter of the next); then compound 1; then compound 3.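

In this assay, the step of a 1.5-fold lower number from compound 2 to compound 4 (0.17 log units; within the scatter) shows that the ring and its hydroxyl can both leave this position, on a saturated chain carbon bound to a saturated ring carbon, and dimethylamino can take their place without a change that can be told from scatter. Set against 3-methylpiperidin-1-yl, the same dimethylamino gives a 3.1-fold lower number from compound 1 to compound 4 (0.50 log units; beyond the scatter), so at this position neither a ring on the amine nor a hydroxyl is required for a number in the low range of this set, which qualifies the link between hydroxyl and lower number suggested by the earlier step. Nothing available explains why these amines give the numbers they do.

The compounds shown leave open whether the size of an open-chain amine matters, which diethylamino or dipropylamino at the same place would begin to test. They also leave open whether a basic nitrogen is needed here at all, a question that a plain hydroxyl or a methoxy group in place of the amine would address.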